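The source may hold more compounds than are shown below. What is called first, only, known or untested is meant among the compounds shown, and "the series" means these compounds.

Measured compounds:
compound 1 `Cc1ccc2[nH]c(C(=O)N[C@H]3CN(S(=O)(=O)c4ccccc4)C[C@@H]3C(=O)NCCN(C)C)cc2c1` — 93%
compound 2 `Cc1ccc2[nH]c(C(=O)N[C@H]3CN(S(=O)(=O)c4cnccn4)C[C@@H]3C(=O)NCCN(C)C)cc2c1` — 92%
compound 3 `Cc1ccc2[nH]c(C(=O)N[C@H]3CN(S(=O)(=O)c4ccccc4)C[C@H]3C(=O)NCCN(C)C)cc2c1` — 72%

In a functional assay on HEK293 cells for agonist activity at growth hormone secretagogue receptor type 1 (Homo sapiens), read by HTRF and inositol phosphate accumulation, with a stated time of 90 min, in the presence of a further agent that is not named here (on this read-out lower numbers stand for smaller maximal responses and higher numbers for larger maximal responses), compound 1 gives 93%, the highest of the three numbers. Putting pyrazin-2-yl in place of phenyl on the sulfonyl sulfur changes little: a number 1 percentage points lower from compound 1 to compound 2 (within the scatter). Within the data shown here, the only step beyond the scatter is a number 21 percentage points lower from compound 1 to compound 3 (beyond the scatter), which rests on (the fact that compounds 1 and 3 differ only in the configuration as drawn).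

Compound 4 `Cc1ccc2[nH]c(C(=O)N[C@H]3CN(S(=O)(=O)c4ccccc4)C[C@@H]3C(=O)N[C@@H]3CCCNC3)cc2c1` differs from compound 1 in one place: piperidin-3-yl in place of 2-(dimethylamino)ethyl on an amide-type nitrogen. Neither measured step touches this amide-type nitrogen, so the measured pairs give no direct guide for it. The one tolerated change, from compound 1 to compound 2, was small, and nothing shown argues for a large drop here. Compound 4 is therefore expected to stay close to compound 1, with a number 5 percentage points lower from compound 1 to compound 4 (within the scatter), at an estimated 88% (range 70% to 100%).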

Compound 4, largest response reached (Emax), in percent of the reference or control that the assay uses: 91%
The estimate for compound 4 lay 3 percentage points below the measured number; low and high end bracket the measured number.
By their numbers in this assay, from the lowest: compound 3; then compounds 4, 2 and 1 (each within the scatter of the next).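

In this assay this amide-type nitrogen now carries a measured change, piperidin-3-yl in place of 2-(dimethylamino)ethyl: a number 2 percentage points lower from compound 1 to compound 4 (within the scatter). The open chain on this nitrogen can thus give way to a six-membered non-aromatic ring with a hydrogen-bond donor while the maximal response stays within the scatter. Nothing at hand accounts for this tolerance.

The compounds shown leave open whether the response holds when the group on this nitrogen has no amine at all, as with cyclohexyl, or carries a carboxylic acid. They also leave open how piperidin-3-yl with its stereocentre in the opposite configuration would read.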